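Swapping Bromo for Methoxy in a Cytotoxic Series

A few compounds are considered here, and "the series" means these few. Any claim that something is new, unique, unknown or untested is made for them only; others in the source may bear on it.

Three measured candidates share one core and differ in the aromatic group at the end of a chain. In a functional assay on PC-3 cells (Homo sapiens) for cytotoxicity, read by MTT assay, with a stated time of 72 h (on this read-out higher numbers stand for weaker inhibition and lower numbers for stronger inhibition), compound 1 `CNC(=O)c1cc(Oc2ccc(C(=O)/C=C/c3ccc(OC)c(OC)c3OC)cc2)ccn1` gives "not determined" (no result reported) and so offers no number to compare. Compound 2 `CNC(=O)c1cc(Oc2ccc(C(=O)/C=C/c3ccc(Br)cc3)cc2)ccn1` gives 18500 nM and compound 3 `CNC(=O)c1cc(Oc2ccc(C(=O)/C=C/c3ccc(F)cc3Cl)cc2)ccn1` gives 4760 nM on the same read-out. Among the measured compounds shown here, compound 2 thus holds the higher of the only two numbers, which makes it the weaker of that pair. For the measured compounds named here, the one measured step is a 3.9-fold lower number from compound 2 to compound 3 (0.59 log units; beyond the scatter) with 2-chloro-4-fluorophenyl in place of 4-bromophenyl.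

Compound 4 `CNC(=O)c1cc(Oc2ccc(C(=O)/C=C/c3ccc(OC)cc3)cc2)ccn1` has not yet been measured. Its difference from compound 2 is methoxy in place of bromo on an aromatic carbon and in words it is methoxy in place of bromo on an aromatic carbon, para to a large group. Going by the values given here, no measured pair shows this exact swap. The measured step also removes the bromo, but it brings in other groups, so it is only a loose guide. Compound 1 carries methoxy groups but has no number to help. In this assay a move toward a lower number is therefore expected, smaller than the measured step and perhaps within the scatter. The expected change is (estimated) a 1.9-fold lower number from compound 2 to compound 4 (0.27 log units; within the scatter) (an uncertain call). Compound 4 is estimated at 10000 nM (expected range 3500 nM to 28000 nM).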

Compound 4, half-maximal inhibitory concentration: > 50000 nM
Compound 4 ended at the assay's limit; the forecaster's own chance of this, stated with the estimate: 10%; middle value at least 5.0-fold (0.69 log units) from the limit.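

Methoxy in place of bromo, on an aromatic carbon para to a large group, gives an at least 2.7-fold higher number from compound 2 to compound 4 (0.43 log units; beyond the scatter), so this single change moves the read-out toward weaker inhibition, a direction that the earlier step, which also removed the bromo, did not show. Compared with the 2-chloro-4-fluorophenyl end group the gap is wider, an at least 10-fold higher number from compound 3 to compound 4 (1.02 log units; beyond the scatter), which shows that the aromatic group at the end of this chain can shift the read-out by a large amount. The entry for compound 4, > 50000 nM, is a limit of this assay and not a number, so both new steps give only a floor for the true size: the limit of > 50000 nM in this assay, at which 1 of the 4 values shown sits.

Among the compounds shown here, compound 1 also carries methoxy groups but offers no number, so it remains open whether adding more of them alongside the one in compound 4 would change this picture. Also open, going by these compounds, is how a hydroxy group, an amine or a carboxylic acid would read on the same aromatic carbon, and whether chloro or fluoro alone would match the pair in compound 3.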